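This account rests on a few compounds, and the source may have more. Where it says the series, first, only, none or still open, it means among the compounds named here.

Measured so far in a functional assay on HCT-15 cells (Homo sapiens) for inhibition, read by sulforhodamine B assay; on this read-out higher numbers stand for weaker inhibition of growth and lower numbers for stronger inhibition of growth:

compound 1, `O=C(CCC1=CCN(CCCc2ccc(Br)cc2)C1=O)NO`: 5100 nM
compound 2, `O=C(CCC1=CCN(Cc2cccc(Br)c2)C1=O)NO`: 4720 nM

Compound 1 holds the highest of the two numbers in this assay, yet compound 2 sits so close that the gap between them lies within the usual scatter; the two readings show no order and no change between them.

Compound 3, `CC(C)c1ccc(CCCN2CC=C(CCC(=O)NO)C2=O)cc1`, is the next compound due for measurement in this assay. It differs from compound 1 in one place: isopropyl in place of bromo on an aromatic carbon. Within the data shown here, no measured pair carries this exchange, so there is no step to lean on, and the two readings in hand give no trend to extend. The step from compound 1 to compound 3 is expected to be a 1.1-fold lower number from compound 1 to compound 3 (0.05 log units; within the scatter), small and in no firm direction, most likely not beyond the scatter. Compound 3 is therefore estimated at 4500 nM, with a range from 1500 nM to 13000 nM.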

Compound 3, concentration for 50% growth inhibition: 5100 nM
Estimate against measurement, compound 3: 1.1-fold (0.05 log units) below; the range from low to high includes it.
By their numbers in this assay, from the lowest: compounds 2, 1 and 3 (each within the scatter of the next).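

In this assay, isopropyl in place of bromo on an aromatic carbon, para to a large group, gives no change at the digits printed from compound 1 to compound 3 (within the scatter). Among these compounds, this is the first one-place exchange that can be read: at this position, a group of three carbon heavy atoms stands in for a single bromine with no reading beyond the scatter. Nothing available bears on the reason for this result.

As far as these compounds go, both groups compared carry no hydrogen-bond donors or acceptors and no net charge, so the effect of an amine or a carboxylic acid on this aromatic carbon remains open. Also open, from the compounds shown here alone, is whether a longer alkyl chain at this position would keep the reading in this assay or shift it beyond the scatter.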